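The compounds below may be only part of what the source reports. "The series", "measured", "known", "first", "only" and "open" are said of these compounds alone.

Measured so far:
compound 1, `CCc1cccc(NC(=O)CN2CCC(c3cccc[n+]3[O-])CC2)c1`: 95 nM
compound 2, `O=C(NCN1CCC(c2cccc[n+]2[O-])CC1)c1cnccc1Cl`: 1290 nM

In a functional assay on HEK293 cells for agonist activity at D(4) dopamine receptor (Homo sapiens), read by FLIPR (a lower number here means that less compound is needed, a higher number that more compound is needed for the effect), compound 1 stands at the lowest of the two numbers; compound 2 sits beyond the scatter above it. Among the measured compounds shown here, no two measured compounds differ in one place only, so no single-change step is known. Compound 3, `O=C(CN1CCC(c2cccc[n+]2[O-])CC1)Nc1cccc(Cl)c1`, differs from compound 1 by chloro in place of ethyl on an aromatic carbon. Nothing measured here bears on that exchange, so a small step is expected, a 1.4-fold higher number from compound 1 to compound 3 (0.14 log units; within the scatter), most likely within the scatter or slightly toward a higher number. Compound 3 is estimated at 130 nM, in a range from 40 nM to 450 nM.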

Compound 3, half-maximal effective concentration: 62 nM
Beside the measured number, compound 3's estimate is 2.1-fold (0.32 log units) above it, and the stated range covers the measured number.
By their numbers in this assay, from the lowest: compounds 3 and 1 (each within the scatter of the next); then compound 2.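

In this assay the series now has its first single-change step: chloro in place of ethyl on an aromatic carbon gives a 1.5-fold lower number from compound 1 to compound 3 (0.19 log units; within the scatter) and leaves the two compounds level. At this place, meta to a large group, the 3-ethylphenyl and 3-chlorophenyl forms therefore cannot be told apart, even though the group that enters has fewer heavy atoms than the one that leaves. No available measurement offers an explanation for this result. Still open, going by these compounds, is how an amine, a carboxylic acid or a longer chain at this place would read, and whether the same exchange would give a similar step on another aromatic carbon.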